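Three Amides Beyond the Limit and a Hydroxyphenyl Newcomer

A few compounds are considered here, and "the series" means these few. Any claim that something is new, unique, unknown or untested is made for them only; others in the source may bear on it.

The shared core of compound 1 `O=C(Nc1ccc(Sc2nc3ccccc3s2)c(Cl)c1)c1cc(Br)cc(Br)c1` is an amide whose anilide half carries a benzothiazole sulfide. In an assay for inhibition of HSP60/HSP10 (Homo sapiens), with a stated time of 60 min (on this read-out higher numbers stand for weaker inhibition and lower numbers for stronger inhibition), compound 1 gives > 100000 nM, which is a limit of the assay rather than a number. Compound 2 `COc1ccc(Br)cc1C(=O)Nc1ccc(Sc2nc3ccccc3s2)cc1` also gives > 100000 nM in this assay, again a limit. Compound 3 `O=C(Nc1cccc(Cl)c1)c1cccc(Br)c1` gives > 100000 nM in this assay, once more a limit. So every measurement here sits at the same edge, because of the limit of > 100000 nM in this assay, at which 3 of the 3 values shown sit; no measured compound has a numerical value, and no step between them can be sized.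

Compound 4 `O=C(Nc1ccc(Sc2nc3ccccc3s2)c(Cl)c1)c1ccccc1O` is to be measured in this assay. It differs from compound 1 in one place: 2-hydroxyphenyl in place of 3,5-dibromophenyl on a carbonyl carbon. Nothing measured here tells how that exchange acts, since all three values are limits. The expectation is therefore cautious: compound 4 is expected to move by an at least 1.2-fold lower number from compound 1 to compound 4 (0.09 log units; that floor lies within the scatter), a step that may be none beyond the scatter, with only a modest chance of a real number appearing. Compound 4 is estimated at 80000 nM, within a range from 10000 nM to 300000 nM.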

Compound 4, half-maximal inhibitory concentration: > 100000 nM
Compound 4 gave a limit, no number; the forecaster's own chance of this, stated with the estimate: 60%; middle value at least 1.2-fold (0.09 log units) away from the limit.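

Swapping 3,5-dibromophenyl for 2-hydroxyphenyl gives no readable step from compound 1 to compound 4, since both results are limits rather than numbers: the limit of > 100000 nM in this assay, at which 4 of the 4 values shown sit.

The compounds shown leave open which structural change, if any, would yield a numerical value in this assay, and therefore which groups on these amides matter.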